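This account rests on a few compounds, and the source may have more. Where it says the series, first, only, none or still open, it means among the compounds named here.

The series rests on one shared core carrying two aryl groups. Compound 1 is `Cc1ccc(S(=O)(=O)c2nc3ccccc3nc2Nc2ccc(Cl)cc2)cc1`; in a functional assay on A549 cells (Homo sapiens) for cytotoxicity, read by MTT assay, with a stated time of 72 h (on this read-out higher numbers stand for weaker inhibition and lower numbers for stronger inhibition), compound 1 gives 54200 nM. Compound 2 is `Cc1ccc(S(=O)(=O)c2nc3ccccc3nc2Nc2ccc(C(F)(F)F)cc2)cc1`, differing from compound 1 by trifluoromethyl in place of chloro on an aromatic carbon. In this assay compound 2 gives 13500 nM, so that a 4.0-fold lower number from compound 1 to compound 2 (0.60 log units; beyond the scatter). Compound 3 is `COc1ccc(S(=O)(=O)c2nc3ccccc3nc2Nc2ccc(Cl)cc2)cc1`; its core differs from that of compound 1 by methoxy in place of methyl on an aromatic carbon. In this assay compound 3 gives 87300 nM, and a 1.6-fold higher number from compound 1 to compound 3 (0.21 log units; within the scatter), so compound 3 and compound 1 cannot be told apart on this read-out, while compound 2 stands apart from both of them.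

Compound 4 is `COc1ccc(S(=O)(=O)c2nc3ccccc3nc2Nc2ccc(C(F)(F)F)cc2)cc1` and has not been measured in this assay. It differs from compound 3 by trifluoromethyl in place of chloro on an aromatic carbon. This is the same change that turns compound 1 into compound 2, at a place described in identical words, and it is the second time it appears among these compounds. The step from compound 3 to compound 4 in this assay is expected to be of similar size to the earlier one, because a 4.0-fold lower number from compound 1 to compound 2 (0.60 log units; beyond the scatter) was recorded when this change was made on the core of compound 1, and the two cores differ only in the methoxy in place of the methyl. The expected step is a 4.0-fold lower number from compound 3 to compound 4 (0.60 log units; beyond the scatter). Compound 4 is accordingly estimated at 22000 nM. For compound 4 the plausible range is expected to run from 9000 nM to 55000 nM.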

Compound 4, half-maximal inhibitory concentration: 4810 nM
The estimate for compound 4 lay 4.6-fold (0.66 log units) above the measured number; measured number outside the range, below it.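

In this assay the new step is an 18-fold lower number from compound 3 to compound 4 (1.26 log units; beyond the scatter), so trifluoromethyl in place of chloro gives a lower number on both cores, but the size of the step does not carry over from one core to the other: the same change on two cores in this assay, a 4.0-fold lower number (0.60 log units; beyond the scatter) from compound 1 to compound 2 and an 18-fold lower number (1.26 log units; beyond the scatter) from compound 3 to compound 4, 4.5-fold (0.66 log units) apart, beyond the scatter of two such steps

The same four compounds can be read the other way round, and methoxy in place of methyl gives a 2.8-fold lower number from compound 2 to compound 4 (0.45 log units; beyond the scatter), whereas that change could not be told apart from scatter on the chloro compounds: the same change on two cores in this assay, a 1.6-fold higher number (0.21 log units; within the scatter) from compound 1 to compound 3 and a 2.8-fold lower number (0.45 log units; beyond the scatter) from compound 2 to compound 4, 4.5-fold (0.66 log units) apart, beyond the scatter of two such steps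

Together these two comparisons show that, among these four compounds, the effect of one change depends on the group at the other place, so a step measured on one core is a poor guide to its size on the other; they rest on a single set of four compounds, however, and show neither why the steps differ nor whether the same would hold for any other pair of groups.

As far as these compounds go, it remains open whether a nitrile or a carboxylic acid in place of the trifluoromethyl, or a longer chain in place of the methoxy, would show the same dependence. From the compounds shown here alone, it is also open whether the gap between the steps would appear on other cells or in another read-out.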